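The source may hold more compounds than are shown below. What is called first, only, known or untested is meant among the compounds shown, and "the series" means these compounds.

Of the compounds shown here, two have been measured in a functional assay on HCT-116 cells (Homo sapiens) for antiproliferative activity, read by sulforhodamine B assay, with a stated time of 72 h; a higher number here means a weaker inhibitor, a lower number a stronger inhibitor. Compound 1 `O=C(N[C@@H]1CNCC[C@H]1c1ccc(Cl)cc1)c1ccc(-c2ncnc3c2CCC3O)s1` gives 23000 nM in this assay. Compound 2 `Cn1ncc(Cl)c1-c1cc(C(=O)N[C@@H]2CN[C@H](CCN3CCCC3)C[C@H]2c2ccc(Cl)c(Cl)c2)oc1Cl` gives 1940 nM in this assay, the lowest of the two numbers, and the gap to compound 1 lies beyond the usual scatter of repeated measurements. Compound 3 `Cn1ncc(Cl)c1-c1cc(C(=O)N[C@@H]2CN[C@H](CC(O)CO)C[C@H]2c2ccc(Cl)c(Cl)c2)oc1Cl` has not yet been measured. It differs from compound 2 in one place only: 1,2-dihydroxyethyl in place of (pyrrolidin-1-yl)methyl on a saturated chain carbon bound to a saturated ring carbon. Everything else in the two structures is the same. For the measured compounds named here, no pair of measured compounds differs by this change, so there is no measured step to lean on, only the single number for compound 2 as a starting point. In this assay the expected change is a 2.1-fold higher number from compound 2 to compound 3 (0.31 log units; beyond the scatter), a small move toward a higher number, at most a little beyond the scatter. Compound 3 is estimated to give about 4000 nM in this assay, with a likely range from 1500 nM to 12000 nM.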

Compound 3, half-maximal inhibitory concentration: 1110 nM
The estimate for compound 3 lay 3.6-fold (0.56 log units) above the measured number; the whole stated range lies above it.
By their numbers in this assay, from the lowest: compounds 3 and 2 (each within the scatter of the next); then compound 1.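

In this assay, the change from 2-(pyrrolidin-1-yl)ethyl to 2,3-dihydroxypropyl gives a 1.7-fold lower number from compound 2 to compound 3 (0.24 log units; within the scatter) and so leaves compound 2 and compound 3 indistinguishable. For the compounds shown here, this is the first sign that, on this saturated chain carbon bound to a saturated ring carbon, the pyrrolidine ring and its nitrogen can be replaced by a chain carrying two hydroxyl groups without a measurable change in the read-out. Nothing available explains why two such different groups read alike.

On these data alone, whether any group at this place affects the number remains open: a plain ethyl chain, a primary amine or a carboxylic acid here would test that in this assay directly. Going by these compounds alone, this change is also seen on only one shared core, so its outcome on other cores is unknown.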